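The source may report more compounds than this note shows. Statements on the series, on what has been measured and on what is new or still open speak of the compounds shown alone.

Measured in a functional assay on U2OS cells (Homo sapiens) for cytotoxicity, read by MTT assay, with a stated time of 48 h; a higher number here means a weaker inhibitor, a lower number a stronger inhibitor:
- Compound 1 `Fc1cccc(-c2nc(Nc3ccccc3F)c3cc(F)ccc3n2)c1`: > 50000 nM (a limit, not a number)
- Compound 2 `Oc1cccc(Nc2nc(-c3cccc(F)c3)nc3ccc(F)cc23)c1`: 33300 nM
- Compound 3 `Nc1cccc(Nc2nc(-c3cccc(F)c3)nc3ccc(F)cc23)c1`: 49700 nM

Compound 3 stands level with compound 2, as the step of a 1.5-fold higher number from compound 2 to compound 3 (0.17 log units; within the scatter) shows. Compound 4 `Cc1ccc(Nc2nc(-c3cccc(F)c3)nc3ccc(F)cc23)cc1` carries 4-methylphenyl in place of 3-aminophenyl on a nitrogen on an aromatic ring. Earlier changes to this group bear on it. These are an at least 1.5-fold lower number from compound 1 to compound 2 (0.17 log units; that floor lies within the scatter) and a number no higher from compound 1 to compound 3 (the limit leaves the size open), and neither shows a readable step beyond the scatter. The change is therefore expected to stay within the scatter in this assay, though compound 4 may also return only a limit. The expected step is a 1.2-fold lower number from compound 3 to compound 4 (0.09 log units; within the scatter). The estimate for compound 4 is 40000 nM, with an expected range from 15000 nM to 70000 nM.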

Compound 4, half-maximal inhibitory concentration: > 50000 nM
Compound 4 was reported as a limit; the forecaster's own chance of this, stated with the estimate: 45%; at least 1.2-fold (0.09 log units) between middle value and limit.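

Compound 4, with 4-methylphenyl on the nitrogen, returns only a limit, so a second group at this position gives no readable number: the limit of > 50000 nM in this assay, at which 2 of the 4 values shown sit. Among the compounds shown here, the only step with a readable floor is an at least 1.5-fold higher number from compound 2 to compound 4 (0.17 log units; that floor lies within the scatter); the steps from compound 3 and compound 1 cannot be read. So 4-methylphenyl, which counts no hydrogen-bond donors or acceptors, brings no lower number in this assay than 3-aminophenyl, which counts one of each.

As far as these compounds go, the data give a number no lower from compound 3 to compound 4 (the limit leaves the size open), and whether any group on this nitrogen gives a number clearly lower stays open. The compounds shown do not tell what a carboxylic acid or a longer amine chain on this ring would do.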